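The source may hold more compounds than are shown below. What is called first, only, known or untested is meant among the compounds shown, and "the series" means these compounds.

Working notes on the series in a functional assay on CHO cells with adenosine receptor A1 (Homo sapiens) as the target, read by cAMP accumulation and immunoassay, with a stated time of 6 min, tested at 0.01 uM; a lower number here means a stronger effect, a higher number a weaker effect of the compound at the concentration tested.

Of the compounds shown here, three of one shared core have been measured. Compound 1, `Nc1scc(CN2CCN(c3ccc(Cl)cc3Cl)CC2)c1C(=O)c1ccc(Cl)cc1`, gives 2%. Compound 2, `Nc1scc(CN2CCN(c3cc(Cl)cc(Cl)c3)CC2)c1C(=O)c1ccc(Cl)cc1`, gives -1%. Compound 3, `Nc1scc(CN2CCN(c3ccncc3)CC2)c1C(=O)c1ccc(Cl)cc1`, gives -4%. The steps of a number 3 percentage points lower from compound 1 to compound 2 (within the scatter), a number 6 percentage points lower from compound 1 to compound 3 (within the scatter) and a number 3 percentage points lower from compound 2 to compound 3 (within the scatter) all fall within the scatter, so compound 3 stands with compounds 1 and 2 as one group of indistinguishable numbers, none of which shows an effect at this concentration that rises beyond the scatter.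

The next compound, compound 4, `Nc1scc(CN2CCN(C3CCCCCC3)CC2)c1C(=O)c1ccc(Cl)cc1`, differs from compound 3 in one place: cycloheptyl in place of pyridin-4-yl on an amine nitrogen in a ring. The measured steps that bear on this change are the two in which pyridin-4-yl entered on the same ring nitrogen, a number 6 percentage points lower from compound 1 to compound 3 (within the scatter) and a number 3 percentage points lower from compound 2 to compound 3 (within the scatter), both within the scatter. Among the compounds with values here, no measured step puts a non-aromatic ring on that nitrogen, so there is no direct precedent for cycloheptyl; what is known is that every exchange at this position so far has left this assay unmoved. The expected step is therefore one within the scatter, a number 4 percentage points higher from compound 3 to compound 4 (within the scatter). Compound 4 is estimated at 0%, with a range from -10% to 10%.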

Compound 4, a percentage reported as activity, at one concentration (the size of the read-out at that concentration, not a potency): 2.9%
Compound 4: the middle estimate sits 2.9 percentage points below what was measured; the measured number falls inside the stated range.
By their numbers in this assay, from the lowest: compounds 3, 2, 1 and 4 (each within the scatter of the next).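

Within the data shown here, compound 4 puts a non-aromatic ring of carbon only on the ring nitrogen for the first time, and in this assay the steps of a number 6.9 percentage points higher from compound 3 to compound 4 (within the scatter) and a number 3.9 percentage points higher from compound 2 to compound 4 (within the scatter) and a number 0.9 percentage points higher from compound 1 to compound 4 (within the scatter) show that this exchange leaves the number as unmoved as the exchanges among aromatic groups did. The position has now carried 2,4-dichlorophenyl, 3,5-dichlorophenyl, pyridin-4-yl and cycloheptyl without any separation among the four numbers, and the exchange of pyridin-4-yl, with its ring nitrogen and hydrogen-bond acceptor, for an all-carbon ring without an acceptor does not change that reading. No measurement is at hand that would account for this flat reading.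

As far as these compounds go, it stays open whether any group on this ring nitrogen can move the number beyond the scatter, for instance a methyl, a benzyl or a longer chain ending in a carboxylic acid. From the compounds shown here alone, it also stays open whether these four compounds would separate at a concentration other than the single one tested here.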